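Compound 4: one amide group exchanged, caecal half-life estimated

A few compounds are considered here, and "the series" means these few. Any claim that something is new, unique, unknown or untested is made for them only; others in the source may bear on it.

Compound 1 `C[C@@H](N[C@H]1CCN(c2ccc(C(=O)NC(CO)(CO)CO)cc2)C1)c1cccc2ccccc12`: > 12 h (a limit)
Compound 2 `C[C@@H](N[C@H]1CCN(c2ccc(C(=O)N(C)[C@@H](O)[C@H](O)[C@H](O)[C@@H](O)CO)cc2)C1)c1cccc2ccccc12`: 11 h
Compound 3 `C[C@@H](N[C@H]1CCN(c2ccc(C(=O)NCCS(=O)(=O)O)cc2)C1)c1cccc2ccccc12`: 0.8 h

In an ADME assay on Caecum (Rattus norvegicus, strain Sprague-Dawley) for metabolic stability, read by LC-MS, tested at 10 uM (a higher number here means that the compound lasts longer, a lower number that the compound disappears faster), compound 1 gives only a limit and no number, as shown by the limit of > 12 h in this assay, at which 1 of the 3 values shown sits; its true standing is therefore open.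

Compound 4 `C[C@@H](N[C@H]1CCN(c2ccc(C(=O)N[C@H](CCCCN)C(=O)O)cc2)C1)c1cccc2ccccc12` keeps the core of compound 1 and changes the group on the amide-type nitrogen: 5-amino-1-carboxypentyl in place of 2-hydroxy-1,1-bis(hydroxymethyl)ethyl on an amide-type nitrogen.

Among the measured compounds shown here, two measured steps bear on this place. One gave an at least 1.0-fold lower number from compound 1 to compound 2 (0.03 log units; that floor lies within the scatter), so it shows no change beyond the scatter. The other gave an at least 15-fold lower number from compound 1 to compound 3 (1.17 log units; beyond the scatter), a large drop. Compound 4 carries no pentahydroxypentyl chain, so compound 3 at 0.8 h is taken as the closer guide, although its 2-sulfoethyl group differs from the entering group and compound 2 at 11 h warns against assuming a drop.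

A sizeable fall is therefore expected, with an estimated at least 4.0-fold lower number from compound 1 to compound 4 (0.60 log units; beyond the scatter) in this assay. For compound 4 the expected half-life is 3 h, with an estimated range from 0.7 h to 12 h.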

Compound 4, half-life: 4.3 h
Estimate against measurement, compound 4: 1.4-fold (0.16 log units) below, within the range that was stated.
By their numbers in this assay, from the lowest: compound 3; then compound 4; then compound 2. At a limit, above all of these: compound 1.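

With 5-amino-1-carboxypentyl on the amide-type nitrogen, the half-life in this assay falls between those of the other groups at this place: the change gave an at least 2.7-fold lower number from compound 1 to compound 4 (0.44 log units; beyond the scatter), while the same group against 2-sulfoethyl gave a 5.4-fold higher number from compound 3 to compound 4 (0.73 log units; beyond the scatter). Against the pentahydroxypentyl amide, the step reads a 2.6-fold lower number from compound 2 to compound 4 (0.41 log units; beyond the scatter). A fall at this place is therefore no longer tied to 2-sulfoethyl alone, and its size differs with the group that enters.

On these data alone, the full size of the step from compound 1 stays open, since compound 1 gives only a limit and no number: the limit of > 12 h in this assay, at which 1 of the 4 values shown sits. The compounds shown also do not separate the two ends of the new group, so how a chain bearing only the amine or only the carboxylic acid would stand remains open.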